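Swapping the morpholine ring for piperidine in compound 1

The compounds below may be only part of what the source reports. "The series", "measured", "known", "first", "only" and "open" are said of these compounds alone.

Measured so far:
compound 1, `N/C(=N\NC(=S)N1CCOCC1)c1ccccn1`: 7300 nM
compound 2, `Cc1ccnc(/C(N)=N/NC(=S)N2CCOCC2)c1`: 38500 nM
compound 3, `Cc1cccc(/C(N)=N/NC(=S)N2CCSCC2)n1`: 1800 nM

In a functional assay on HeLa cells (Homo sapiens) for cytotoxicity, read by MTT assay, with a stated time of 72 h (a lower number here means a stronger inhibitor, a higher number a weaker inhibitor), compound 1 stands second highest of the three numbers; compound 3 gives 1800 nM and compound 2 gives 38500 nM. For the measured compounds named here, the only single-point step among the measured compounds is a 5.3-fold higher number from compound 1 to compound 2 (0.72 log units; beyond the scatter), a change on the aromatic ring. Compound 4 `N/C(=N\NC(=S)N1CCCCC1)c1ccccn1` instead carries piperidin-1-yl in place of morpholin-4-yl on a thiocarbonyl carbon. Going by the values given here, no measured step touches this part of the molecule, so the step from compound 1 to compound 4 cannot be read from a precedent here. In the absence of such a precedent a change no larger than the scatter is expected, a 1.3-fold lower number from compound 1 to compound 4 (0.12 log units; within the scatter), and compound 4 is estimated at 5500 nM in this assay, ranging from 1500 nM to 20000 nM.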

Compound 4, half-maximal inhibitory concentration: 3800 nM
For compound 4 the middle estimate is 1.4-fold (0.16 log units) above the measured one; the measured number falls inside the stated range.
By their numbers in this assay, from the lowest: compound 3; then compounds 4 and 1 (each within the scatter of the next); then compound 2.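

In this assay piperidin-1-yl in place of morpholin-4-yl on the thiocarbonyl carbon gives a 1.9-fold lower number from compound 1 to compound 4 (0.28 log units; within the scatter) and so stays within the usual scatter. For the compounds shown here, this is the only measured step at this position, since the earlier step lay on the aromatic ring, and it shows that the ring oxygen of morpholin-4-yl can go without a change beyond the scatter. Nothing available here offers an explanation for this outcome.

Going by these compounds, whether piperazin-1-yl, which carries a second ring nitrogen, or an open-chain group such as dimethylamino would be tolerated on this carbon remains open. Also open, on these data alone, is whether a methyl on the aromatic ring would have the same effect alongside piperidin-1-yl as alongside morpholin-4-yl.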